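Working notes: hydroxy for methoxy at a cytotoxicity limit

This account rests on a few compounds, and the source may have more. Where it says the series, first, only, none or still open, it means among the compounds named here.

Compound 1 `COc1cc(C)cc(-c2nn(CC#N)cc2-c2ccc(-c3cccc(C(C)=O)c3)nc2)c1`: in a functional assay on SR cells (Homo sapiens) for inhibition, read by sulforhodamine B assay, with a stated time of 48 h (on this read-out lower numbers stand for higher toxicity in this test and higher numbers for lower toxicity in this test), compound 1 reports only a limit, > 100000 nM.
Compound 2 `Cc1cc(O)cc(-c2nn(CC#N)cc2-c2ccnc(-c3ccc(Oc4ccccc4)cc3)c2)c1`: compound 2 likewise reports a limit, > 100000 nM.
Compound 3 `COc1cc(C)cc(-c2nn(CC#N)cc2-c2ccnc(-c3ccc(N(C)C)cc3)c2)c1`: for compound 3 only a limit is reported, > 100000 nM.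

Where compound 3 stands is thus only bounded: its value in this assay is a limit rather than a number, and the same holds for the other two compounds, all resting at the limit of > 100000 nM in this assay, at which 3 of the 3 values shown sit. Going by the values given here, no measured pair differs in a single place, so no step size can be read from the series. Compound 4 `Cc1cc(O)cc(-c2nn(CC#N)cc2-c2ccnc(-c3ccc(N(C)C)cc3)c2)c1` differs from compound 3 by hydrogen in place of methyl on an oxygen on an aromatic ring. Compound 2 already carries the hydroxy form and also reports a limit. No shift beyond the scatter is therefore expected. For compound 4 the estimate in this assay is 100000 nM, with a range from 40000 nM to 300000 nM. The step from compound 3 to compound 4 is estimated as a number no higher from compound 3 to compound 4 (the limit leaves the size open).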

Compound 4, concentration lethal to 50% of the cells: > 100000 nM
Compound 4: a limit, no number (the forecaster's own chance of this, stated with the estimate: 85%); the middle value sits exactly at the limit.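

Compound 4, like compound 3 and compound 2, reports only a limit, so neither step to compound 4 can be read. The compounds shown leave open what methoxy to hydroxy does to a measured value, since all remain unquantified: the limit of > 100000 nM in this assay, at which 4 of the 4 values shown sit.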